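The source may report more compounds than this note shows. Statements on the series, on what has been measured and on what is new or still open speak of the compounds shown alone.

Working notes on the amide series.

Three compounds carry numbers in a functional assay on U-251 cells (Homo sapiens) for antiproliferative activity, read by sulforhodamine B assay, with a stated time of 48 h; on this read-out lower numbers stand for stronger inhibition of growth and higher numbers for weaker inhibition of growth. Compound 1 `CCCCCC[C@@H](O)C/C=C\CCCCCCCC(=O)N[C@@H](C)c1ccccc1` gives 3.6 ug/mL. Compound 2 `CCCCCCCCCCCCCCCCCC(=O)N1CCOCC1` gives 39.9 ug/mL. Compound 3 `CCCCC/C=C\C/C=C\CCCCCCCC(=O)N1CCCCC1` gives 44.2 ug/mL. On these numbers compound 2 stands second highest of the three; its nearest neighbour is compound 3, whose number sits within the usual scatter of compound 2, so no order between them is claimed. Compound 1 stands furthest from compound 2, with a number beyond the scatter and on the stronger-inhibition side.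

The step to be followed runs from compound 2 to the unmeasured compound 4 `CCCCCCCCCCCCCCCCCC(=O)N1CCCC1`. The change is pyrrolidin-1-yl in place of morpholin-4-yl on a carbonyl carbon. For the measured compounds named here, no measured pair in the set isolates this change, so nothing in the data shows its size or direction. Given that compound 2 and compound 3 give numbers within the scatter of each other despite different ring amides and different chains, the expectation for this assay is a step of no size beyond the scatter, a 1.1-fold lower number from compound 2 to compound 4 (0.06 log units; within the scatter), in either direction. Compound 4 is accordingly estimated at 35 ug/mL, with a range from 15 ug/mL to 80 ug/mL.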

Compound 4, concentration for 50% growth inhibition: 8 ug/mL
The estimate for compound 4 lay 4.4-fold (0.64 log units) above the measured number; the whole stated range lies above it.
By their numbers in this assay, from the lowest: compound 1; then compound 4; then compounds 2 and 3 (each within the scatter of the next).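

In this assay, pyrrolidin-1-yl in place of morpholin-4-yl on a carbonyl carbon whose other neighbour is a saturated chain carbon gives a 5.0-fold lower number from compound 2 to compound 4 (0.70 log units; beyond the scatter), a step beyond the scatter with the chain unchanged. For the compounds shown here, the ring amide at this position can therefore move the number on its own, which the earlier compounds could not show, since compound 2 and compound 3 differ in both the ring amide and the chain. The change alters ring size and removes the ring oxygen together, and no measurement at hand accounts for the step.

The compounds shown leave open whether the step follows the ring size or the loss of the oxygen, a question that piperidin-1-yl on the same saturated chain would address. Also open, from the compounds shown here alone, is whether the step carries over to other chains, such as the chain of compound 3 bearing pyrrolidin-1-yl.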